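Removing the sec-butyl on the deprotected core

The compounds below may be only part of what the source reports. "The series", "measured", "known", "first", "only" and "open" are said of these compounds alone.

This account concerns four related compounds. Compound 1 `CC[C@H](C)[C@H](NCCC1OCC(C)(C)CO1)C(=O)N[C@H]1[C@@H](OCc2ccccc2)O[C@H](COCc2ccccc2)[C@@H](OCc2ccccc2)[C@@H]1OCc1ccccc1` and compound 2 `C[C@H](NCCC1OCC(C)(C)CO1)C(=O)N[C@H]1[C@@H](OCc2ccccc2)O[C@H](COCc2ccccc2)[C@@H](OCc2ccccc2)[C@@H]1OCc1ccccc1` carry a protected core, while compound 3 `CC[C@H](C)[C@H](NCCC1OCC(C)(C)CO1)C(=O)N[C@H]1C(O)O[C@H](CO)[C@@H](O)[C@@H]1O` and compound 4 `C[C@H](NCCC1OCC(C)(C)CO1)C(=O)N[C@H]1C(O)O[C@H](CO)[C@@H](O)[C@@H]1O` carry the free core. In a functional assay on the whole organism (Ear, strain ICR) for inhibition, with Mus musculus as the target, with stated times of 30 min and 2 h, at a dose of 10 umol/kg by the oral route (a higher number here means more inhibition at the dose given (going by the name of the read-out), a lower number less inhibition), compound 1 gives 81.6%, compound 2 gives 90.3%, and compound 3 gives 88.7%. Among the three numbers compound 3 stands second highest, with compound 2 nearest and compound 1 furthest, both gaps within the scatter.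

The change from compound 3 to compound 4 is methyl in place of sec-butyl on a saturated chain carbon bound to an amine nitrogen and a carbonyl carbon. For the measured compounds named here, the same change on the protected core is the one measured step that bears on it: a number 8.7 percentage points higher from compound 1 to compound 2 (within the scatter) in this assay. That step stayed within the scatter, so compound 4 is expected to differ from compound 3 by no more than the scatter, with an expected step of a number 2.3 percentage points higher from compound 3 to compound 4 (within the scatter) in this assay. Compound 4 is therefore estimated at 91%, in a range from 80% to 98%.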

Compound 4, a percentage reported as inhibition, in the whole organism at one dose (the size of the read-out at that dose, not a potency): 86.8%
Compound 4: middle estimate off by 4.2 percentage points, on the high side, within the range that was stated.
By their numbers in this assay, from the lowest: compounds 1, 4, 3 and 2 (each within the scatter of the next).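

On the free core, methyl in place of sec-butyl on a saturated chain carbon bound to an amine nitrogen and a carbonyl carbon now has its own measured step in this assay: a number 1.9 percentage points lower from compound 3 to compound 4 (within the scatter). The change has thus been read on both cores, and on neither does it move the read-out beyond the scatter. Nor do the two steps differ from each other beyond the scatter, so the shared change shows no dependence on the core: the same change on two cores in this assay, a number 8.7 percentage points higher (within the scatter) from compound 1 to compound 2 and a number 1.9 percentage points lower (within the scatter) from compound 3 to compound 4, 10.6 percentage points apart, within the scatter of two such steps.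

As far as these compounds go, what a group carrying a carboxylic acid or an amine at this position would do remains open. The read-out also comes from a single dose and is not a potency, so these compounds leave open whether sec-butyl and methyl would separate at other doses.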